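Swapping the benzothiazole for a methylphenyl amide

The compounds below may be only part of what the source reports. "The series", "measured", "known", "first", "only" and "open" are said of these compounds alone.

Compound 1 `CC(C)[C@@H](NC(=O)c1nc2ccccc2s1)C(=O)N1CCC(c2ccc(Cl)cc2)CC1` is the stronger of the two compounds measured in an assay on THP-1 cells for displacement of a labelled ligand from C-C chemokine receptor type 1 (Homo sapiens); on this read-out lower numbers stand for stronger inhibition and higher numbers for weaker inhibition: compound 1 gives 18 nM, whereas compound 2 `CC(C)C(NC(=O)c1ccccc1)C(=O)N1CCN(c2ccc(Cl)cc2)CC1`, which differs in several places, gives 525 nM. Compound 3 `Cc1ccccc1C(=O)N[C@@H](C(=O)N1CCC(c2ccc(Cl)cc2)CC1)C(C)C` differs from compound 1 only in one place: 2-methylphenyl in place of 1,3-benzothiazol-2-yl on a carbonyl carbon. Among the measured compounds shown here, no measured pair isolates this change, but the weaker number of compound 2 with its plain benzoyl group suggests the benzothiazole matters. Compound 3 is expected to be weaker, with a step of an 8.3-fold higher number from compound 1 to compound 3 (0.92 log units; beyond the scatter) beyond the scatter. Compound 3 is estimated at 150 nM, between 40 nM and 600 nM.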

Compound 3, half-maximal inhibitory concentration: 32 nM
Compound 3: middle estimate off by 4.7-fold (0.67 log units), on the high side; the whole stated range lies above it.
By their numbers in this assay, from the lowest: compounds 1 and 3 (each within the scatter of the next); then compound 2.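

In this assay the change gives a 1.8-fold higher number from compound 1 to compound 3 (0.25 log units; within the scatter), so at this carbonyl carbon 2-methylphenyl can take the place of 1,3-benzothiazol-2-yl with no difference beyond the scatter. The five-membered aromatic ring and its 2 hydrogen-bond acceptors are therefore not needed for a value in this range on the core of compound 1. No measurement at hand explains why the two groups read alike. The compounds shown leave open what the methyl group contributes on this core, and how an amine or a carboxylic acid on the phenyl ring would read.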